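The compounds below may be only part of what the source reports. "The series", "measured", "known", "first", "only" and "open" are said of these compounds alone.

Of the compounds shown here, three built on a shared core have been tested in a functional assay on PC-12 cells (Rattus norvegicus) for cytotoxicity, read by MTT assay, with stated times of 2 h and 24 h, tested at 1 uM; a higher number here means a stronger effect of the compound at the concentration tested, a lower number a weaker effect. Compound 1 `COc1ccc(-n2nc(-c3ccc(C(F)(F)F)cc3O)nc2-c2ccccc2O)cc1` gives 69%, compound 2 `COc1ccccc1-n1nc(-c2ccc(C(F)(F)F)cc2O)nc1-c1ccccc1O` gives 70.7%, and compound 3 `Oc1cc(C(F)(F)F)ccc1-c1nc(-c2ccccc2O)n(-c2cccc(C(F)(F)F)c2)n1` gives 71.5%. On these numbers compound 3 stands highest of the three, yet the step of a number 0.8 percentage points higher from compound 2 to compound 3 (within the scatter) and the step of a number 2.5 percentage points higher from compound 1 to compound 3 (within the scatter) both fall within the usual scatter of this measurement, as does the step of a number 1.7 percentage points higher from compound 1 to compound 2 (within the scatter), so the three compounds cannot be told apart.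

Compound 4 `Oc1cc(C(F)(F)F)ccc1-c1nc(-c2ccccc2O)n(-c2ccc(F)cc2F)n1` is the next compound to be measured. It differs from compound 3 in one place: 2,4-difluorophenyl in place of 3-(trifluoromethyl)phenyl on an aromatic nitrogen. The same position, the aromatic nitrogen of the five-membered ring, is exactly where the three measured compounds differ from one another. There a 4-methoxyphenyl, a 2-methoxyphenyl and a 3-(trifluoromethyl)phenyl group have been tried, and every exchange among them moved the read-out by less than the scatter. For the measured compounds named here, the swap to a 2,4-difluorophenyl group has no measured precedent of its own, but nothing in the three steps suggests that this position drives the read-out. The step from compound 3 to compound 4 in this assay is therefore expected to be small, a number 0.5 percentage points lower from compound 3 to compound 4 (within the scatter), in no particular direction. Compound 4 is estimated to give 71%, with a likely range from 58% to 82%.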

Compound 4, a percentage reported as activity, at one concentration (the size of the read-out at that concentration, not a potency): 65.9%
Compound 4: middle estimate off by 5.1 percentage points, on the high side; measured number inside the range.
By their numbers in this assay, from the lowest: compounds 4, 1, 2 and 3 (each within the scatter of the next).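

In this assay a fourth group on the aromatic nitrogen, 2,4-difluorophenyl, still cannot be told apart from the other three, with a number 5.6 percentage points lower from compound 3 to compound 4 (within the scatter) and a number 4.8 percentage points lower from compound 2 to compound 4 (within the scatter) and a number 3.1 percentage points lower from compound 1 to compound 4 (within the scatter) as the three new steps. The earlier compounds showed this only for methoxyphenyl and trifluoromethylphenyl groups, whereas all four compounds now show that a phenyl ring carrying only fluorine on this nitrogen also gives a read-out that stays within the scatter of the others, so no group at this position stands out among those shown. No measurement is available that would explain the small differences among these four compounds.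

Every group shown on this nitrogen is a substituted phenyl ring, so it remains open what a short alkyl chain would do there, or a phenyl ring carrying an amine or a carboxylic acid. The 2-hydroxyphenyl and 2-hydroxy-4-(trifluoromethyl)phenyl groups are the same in all four compounds, which leaves the effect of any change at those two places unknown.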